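The source may report more compounds than this note shows. Statements on the series, on what has been measured and on what is new or still open speak of the compounds shown alone.

Compound 1 `C=CCN(CC=C)C(=O)[C@@]1(c2ccsc2)C[C@H]1CN` gives 59 mL/min/kg in an in vitro ADME assay on microsomes from liver (Rattus norvegicus) for metabolic stability; a lower number here means slower removal, a higher number faster removal of the compound. Compound 2 `C=CCN(CCOC)C(=O)[C@@]1(c2ccsc2)C[C@H]1CN`, which carries methoxymethyl in place of vinyl on a saturated chain carbon bound to an amide-type nitrogen, gives 52 mL/min/kg in this assay; the step of a 1.1-fold lower number from compound 1 to compound 2 (0.05 log units; within the scatter) leaves the two numbers within the scatter of each other. Compound 3 `C=C(F)CN(CCOC)C(=O)[C@@]1(c2ccsc2)C[C@H]1CN` differs from compound 2 by fluoro in place of hydrogen on a double-bonded chain carbon bound to a saturated chain carbon. Among the compounds with values here, no measured step touches this double-bonded chain carbon, and the one known step, a 1.1-fold lower number from compound 1 to compound 2 (0.05 log units; within the scatter), was small at another site, so no shift beyond the scatter is expected. For compound 3 the expected step is a 1.0-fold lower number from compound 2 to compound 3 (0.02 log units; within the scatter), giving an estimate of 50 mL/min/kg with a range from 28 mL/min/kg to 90 mL/min/kg.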

Compound 3, clearance: 54 mL/min/kg
The estimate for compound 3 lay 1.1-fold (0.03 log units) below the measured number; the range from low to high includes it.
By their numbers in this assay, from the lowest: compounds 2, 3 and 1 (each within the scatter of the next).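

In this assay, fluoro in place of hydrogen on a double-bonded chain carbon bound to a saturated chain carbon gives a 1.0-fold higher number from compound 2 to compound 3 (0.02 log units; within the scatter), so this position, untouched by the earlier step, now has a first reading, and it lies within the scatter. Compound 2 and compound 3 cannot be told apart here, just as compound 1 and compound 2 could not be at the other site. Nothing at hand bears on why this is so.

On these data alone, whether a larger group on this carbon, such as trifluoromethyl or a longer chain, would move the number beyond the scatter remains open. So does the effect of an amine on the chain.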